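A few compounds are considered here, and "the series" means these few. Any claim that something is new, unique, unknown or untested is made for them only; others in the source may bear on it.

Measured so far:
- compound 1 `O=c1cc(-c2ccc([N+](=O)[O-])cc2)oc2cc(O)ccc12`: 21.8 ug/mL
- compound 2 `O=c1cc(-c2ccc([N+](=O)[O-])cc2)oc2c(O)c(O)ccc12`: 2.56 ug/mL
- compound 3 `COc1cc(-c2cc(=O)c3ccc(O)cc3o2)cc(OC)c1O[Si](C)(C)C(C)(C)C`: 5.3 ug/mL

In a functional assay on A549 cells (Homo sapiens) for cytotoxicity, read by MTT assay, with a stated time of 6 days (on this read-out higher numbers stand for an effect only at larger amounts of compound and lower numbers for an effect already at smaller amounts), compound 1 gives 21.8 ug/mL. Compound 2 carries the change (hydroxy in place of hydrogen on an aromatic carbon), and this gives an 8.5-fold lower number from compound 1 to compound 2 (0.93 log units; beyond the scatter). Compound 3 stands on a different core; the difference between the two cores is not broken down here. In this assay compound 3 gives 5.3 ug/mL, a number between those of compound 1 and compound 2.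

Compound 4 `COc1cc(-c2cc(=O)c3ccc(O)c(O)c3o2)cc(OC)c1O[Si](C)(C)C(C)(C)C` has not yet been measured. It arises from compound 3 by hydroxy in place of hydrogen on an aromatic carbon, the same change that leads from compound 1 to compound 2. Because that earlier change gave an 8.5-fold lower number from compound 1 to compound 2 (0.93 log units; beyond the scatter), a step in the same direction is expected here, though somewhat smaller since the core differs. The expected step is a 4.1-fold lower number from compound 3 to compound 4 (0.61 log units; beyond the scatter). Compound 4 is therefore estimated at 1.3 ug/mL in this assay, expected between 0.5 ug/mL and 3.5 ug/mL.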

Compound 4, concentration for half-maximal effect: 3.31 ug/mL
The estimate for compound 4 lay 2.5-fold (0.41 log units) below the measured number; low and high end bracket the measured number.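

On the core of compound 3, hydroxy in place of hydrogen on an aromatic carbon gave a 1.6-fold lower number from compound 3 to compound 4 (0.20 log units; within the scatter) in this assay, so no change in the number can be claimed there. The two steps differ: the same change on two cores in this assay, an 8.5-fold lower number (0.93 log units; beyond the scatter) from compound 1 to compound 2 and a 1.6-fold lower number (0.20 log units; within the scatter) from compound 3 to compound 4, 5.3-fold (0.73 log units) apart, beyond the scatter of two such steps. The size of the step on the core of compound 1 therefore did not carry over to the core of compound 3, but these two pairs do not show which part of the cores accounts for the gap, or how the change would behave on any further core.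

As far as these compounds go, it remains open whether an amine or a carboxylic acid in place of the added hydroxy would give a step like either of these. From the compounds shown here alone, it is also open whether the gap between the two steps would persist on other cores.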